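This account rests on a few compounds, and the source may have more. Where it says the series, first, only, none or still open, it means among the compounds named here.

Measured so far:

- compound 1, `CCCC[C@@H](O)C(=O)N1N=CC[C@H]1C(=O)NCc1cc(Cl)ccc1-n1cnnn1`: 610 nM
- compound 2, `O=C(NCc1cc(Cl)ccc1-n1cnnn1)[C@@H]1C[C@@H]2C[C@@H]2N1C(=O)[C@H](O)c1cccc(Cl)c1`: 1000 nM
- compound 3, `CC(C)(C)[C@@H](O)C(=O)N1CC[C@@H]2C[C@@]21C(=O)NCc1cc(Cl)ccc1-n1cnnn1`: 1500 nM

All three numbers come from a functional assay on a cell-free system (plasma, Homo sapiens), with a stated time of 3 min; on this read-out higher numbers stand for weaker inhibition and lower numbers for stronger inhibition. In this assay compound 2 gives 1000 nM, the second highest of the three; its nearest neighbour is compound 3, and the widest gap is to compound 1, yet both gaps lie within the scatter, so no order among the three can be read. The shared core carries the chlorophenyl-tetrazole amide throughout, and the hydroxy acid side chain varies: a butyl chain in compound 1, a tert-butyl in compound 3, a 3-chlorophenyl in compound 2.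

Compound 4, `CC(C)(C)OC[C@@H](O)C(=O)N1[C@H](C(=O)NCc2cc(Cl)ccc2-n2cnnn2)C[C@@H]2C[C@@H]21`, is not yet measured in this assay. It differs from compound 2 by (tert-butoxy)methyl in place of 3-chlorophenyl on a saturated chain carbon bound to a carbonyl carbon and an oxygen on a saturated carbon. Among the compounds with values here, no single-change step between measured compounds is available, so the expected step of a 1.1-fold lower number from compound 2 to compound 4 (0.05 log units; within the scatter) is taken as none beyond the scatter; the side-chain variants in compound 1 and compound 3 give numbers in the same band, which supports that expectation. Compound 4 is therefore estimated at 900 nM, within 300 nM to 2700 nM.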

Compound 4, half-maximal inhibitory concentration: 500 nM
Compound 4: the middle estimate sits 1.8-fold (0.26 log units) above what was measured; the measured number falls inside the stated range.
By their numbers in this assay, from the lowest: compounds 4, 1, 2 and 3 (each within the scatter of the next, the first and the last beyond it).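

Within the data shown here, this is the first step that changes one place only: in this assay, (tert-butoxy)methyl in place of 3-chlorophenyl gives a 2.0-fold lower number from compound 2 to compound 4 (0.30 log units; within the scatter). On a saturated chain carbon bound to a carbonyl carbon and an oxygen on a saturated carbon, a six-membered aromatic ring carrying chlorine can therefore give way to an open chain with an ether oxygen without a step beyond the scatter. Nothing measured here speaks to why the two groups read alike.

Going by these compounds, whether an amine, a carboxylic acid or a longer chain at this place would stay in the same band remains open. Also open, on these data alone, is whether the same exchange would read alike on the cores of compound 1 and compound 3.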